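This account rests on a few compounds, and the source may have more. Where it says the series, first, only, none or still open, it means among the compounds named here.

Among the measured compounds shown here, in a functional assay for inhibition, with Rattus norvegicus as the target (on this read-out lower numbers stand for stronger inhibition and higher numbers for weaker inhibition), the two compounds measured so far give a thin base for prediction. Compound 1 `C[C@@H](/N=c1\c(O)c(O)\c1=N/c1ccc(C#N)cc1)C(C)(C)C` has two entries that disagree widely, 370 nM; 24300 nM (2 entries), so it offers no single number to build on. For the measured compounds named here, compound 2 `C[C@@H](/N=c1\c(O)c(O)\c1=N/c1ccc(C#N)cc1Cl)C(C)(C)C` gives 41 nM, making it the only compound here with a single number, and that value lies below both entries of compound 1. On this read-out, a lower number means stronger inhibition.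

The next compound to be tested is compound 3 `C[C@@H](/N=c1\c(O)c(O)\c1=N/c1ccc(C#N)cc1Br)C(C)(C)C`. It keeps the structure of compound 2 except for one change: bromo in place of chloro on an aromatic carbon. Going by the values given here, no measured pair shows what this exchange does in this assay, so the expectation has to start from compound 2 at 41 nM and remains uncertain. The expected 1.0-fold lower number from compound 2 to compound 3 (0.01 log units; within the scatter) is small, with no clear direction and nothing beyond the usual scatter. Compound 3 is therefore estimated at 40 nM, with an expected range of 14 nM to 120 nM.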

Compound 3, half-maximal inhibitory concentration: 75 nM
Beside the measured number, compound 3's estimate is 1.9-fold (0.27 log units) below it, within the range that was stated.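

Among the compounds shown here, the exchange of chloro for bromo gives the first readable step at this position, on the six-membered aromatic ring of carbon only, ortho to a large group and meta to a cyano group: in this assay it gives a 1.8-fold higher number from compound 2 to compound 3 (0.26 log units; within the scatter) and so cannot be told apart from no difference at all. Compound 2 and compound 3 therefore give two halogens at this place whose numbers repeated measurement would not be expected to separate, and compound 3 is the second compound here with a single number. This holds for this one exchange only and does not explain why the two groups read alike.

From the compounds shown here alone, whether a fluoro group, a methoxy group or an amine at this same place would also stay within the scatter of compound 2 remains open. Also open is how much a halogen at this place matters compared with the hydrogen that compound 1 carries there, since compound 1 offers no single number to compare against: the several entries of compound 1 in this assay, 370 nM; 24300 nM (2 entries)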